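Swapping the aryl group at the chain terminus of compound 1

A few compounds are considered here, and "the series" means these few. Any claim that something is new, unique, unknown or untested is made for them only; others in the source may bear on it.

Compound 1, `CC1(C)CCC[C@]2(C)[C@@H](CC[C@@](C)(O)/C=C/c3cccc([N+](=O)[O-])c3)[C@](C)(O)CC[C@@H]12`, is one of three analogues that share a core and differ only in the aromatic group on the double-bonded chain. In a functional assay on HeLa cells (Homo sapiens) for cytotoxicity, read by MTT assay, with a stated time of 48 h (on this read-out higher numbers stand for weaker inhibition and lower numbers for stronger inhibition), compound 1 gives 3380 nM, level with compound 2, `Cc1ccc(C)c(/C=C/[C@](C)(O)CC[C@@H]2[C@@]3(C)CCCC(C)(C)[C@@H]3CC[C@@]2(C)O)c1`, which gives 3380 nM; together they hold the lowest numbers of the three. Compound 3, `CC1(C)CCC[C@]2(C)[C@@H](CC[C@@](C)(O)/C=C/c3ccc(Br)cc3)[C@](C)(O)CC[C@@H]12`, gives 45900 nM, and the step of a 14-fold higher number from compound 1 to compound 3 (1.13 log units; beyond the scatter) is large, as is a 14-fold higher number from compound 2 to compound 3 (1.13 log units; beyond the scatter), whereas no change at the digits printed from compound 1 to compound 2 (within the scatter).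

Compound 4, `CC1(C)CCC[C@]2(C)[C@@H](CC[C@@](C)(O)/C=C/c3ccc(F)cc3)[C@](C)(O)CC[C@@H]12`, is the unmeasured member. Relative to compound 1 the change is 4-fluorophenyl in place of 3-nitrophenyl on a double-bonded chain carbon bound to a double-bonded chain carbon. Going by the values given here, the step most relevant to it is the one to compound 3, since both 4-bromophenyl and 4-fluorophenyl replace 3-nitrophenyl at the same place, and that step was a 14-fold higher number from compound 1 to compound 3 (1.13 log units; beyond the scatter). Among the compounds with values here, the two methyl-substituted and nitro-substituted rings gave the same number, so the move to a single substituent of this kind is the only guide. A higher number is therefore expected for compound 4, estimated as a 5.9-fold higher number from compound 1 to compound 4 (0.77 log units; beyond the scatter), giving an expected value of 20000 nM with a range from 6000 nM to 70000 nM.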

Compound 4, half-maximal inhibitory concentration: 3460 nM
For compound 4 the middle estimate is 5.8-fold (0.76 log units) above the measured one; measured number outside the range, below it.
By their numbers in this assay, from the lowest: compounds 1, 2 and 4 (each within the scatter of the next); then compound 3.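

In this assay the 4-fluorophenyl ring sits level with the 3-nitrophenyl ring (a 1.0-fold higher number from compound 1 to compound 4 (0.01 log units; within the scatter)) and with the 2,5-dimethylphenyl ring (a 1.0-fold higher number from compound 2 to compound 4 (0.01 log units; within the scatter)), so among these compounds, leaving 3-nitrophenyl for a ring with one substituent does not by itself raise the number. Going by these compounds alone, the single exchange of fluoro in place of bromo on an aromatic carbon (a 13-fold lower number from compound 3 to compound 4 (1.12 log units; beyond the scatter)) ties the large gap to that one atom, leaving compound 3 alone among the four. Nothing measured here explains the gap between the bromo and fluoro compounds.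

Going by these compounds, it remains open whether chloro at that aromatic carbon would go with fluoro or with bromo. The compounds shown also do not tell how an unsubstituted phenyl or a pyridine ring at the chain terminus would read.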